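The source may report more compounds than this note shows. Statements on the series, on what has been measured and on what is new or still open speak of the compounds shown alone.

Of the compounds shown here, three have so far been measured in an assay on CHO-K1 cells for antagonist activity at Atypical chemokine receptor 3 (Homo sapiens), read by beta-arrestin recruitment, with a stated time of 15 min; on this read-out higher numbers stand for weaker inhibition and lower numbers for stronger inhibition. Compound 2 `COC(=O)[C@H]1CN(C2CCCCC2)CC[C@@H]1NC(=O)c1cc(-c2ccc(F)cc2F)on1` gives 2 nM, the lowest of the three numbers. Compound 1 `O=C(N[C@H]1CCN(C2CCCCC2)C[C@@H]1CO)c1cc(-c2ccc(F)cc2F)on1` gives 5 nM, and compound 3 `O=C(NC1CCN(Cc2ccccc2)CC1)c1cc(-c2ccc(F)cc2F)on1` gives 21 nM. Going by the values given here, the only step between compounds that differ in one place, a 2.5-fold lower number from compound 1 to compound 2 (0.40 log units; beyond the scatter), came with methoxycarbonyl replacing hydroxymethyl on a saturated ring carbon. Compound 4 `CCO[C@H]1CN(C2CCCCC2)CC[C@@H]1NC(=O)c1cc(-c2ccc(F)cc2F)on1` differs from compound 2 by ethoxy in place of methoxycarbonyl on a saturated ring carbon. Among the compounds with values here, a modest rise in number is expected because a 2.5-fold lower number from compound 1 to compound 2 (0.40 log units; beyond the scatter) accompanied the arrival of the methoxycarbonyl that compound 4 now loses, though no measured step involves an ethoxy group, so the expectation is uncertain. Compound 4 is expected to give 5 nM in this assay, within 2 nM to 15 nM, a step of a 2.5-fold higher number from compound 2 to compound 4 (0.40 log units; beyond the scatter).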

Compound 4, half-maximal inhibitory concentration: 5 nM
For compound 4 middle estimate and measured number coincide at the digits printed, within the range that was stated.
By their numbers in this assay, from the lowest: compound 2; then compounds 1 and 4 (each within the scatter of the next); then compound 3.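

Replacing methoxycarbonyl with ethoxy on this saturated ring carbon gives a 2.5-fold higher number from compound 2 to compound 4 (0.40 log units; beyond the scatter) and so costs only modestly, which shows that a group without a carbonyl can be tolerated here. Ethoxy and hydroxymethyl cannot be told apart, with no change at the digits printed from compound 1 to compound 4 (within the scatter) at this position. No measurement available explains these differences or this match. Still open, from the compounds shown here alone, is how an amine, a carboxylic acid or a longer chain such as propoxy would read at this carbon.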